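A few compounds are considered here, and "the series" means these few. Any claim that something is new, unique, unknown or untested is made for them only; others in the source may bear on it.

Compound 1, `CCOC(=O)CCC(=O)N1CCN(CCCOc2cc3c(Nc4ccc(F)c(Cl)c4)ncnc3cc2OC)CC1`, in a functional assay on A549 cells (Homo sapiens) for cytotoxicity, read by MTT assay, with a stated time of 24 h, tested at 20 uM (a higher number here means a weaker effect of the compound at the concentration tested, a lower number a stronger effect), gives 70%.
Compound 2, `CCCCCCOC(=O)CCC(=O)N1CCN(CCCOc2cc3c(Nc4ccc(F)c(Cl)c4)ncnc3cc2OC)CC1`, gives 85.1%.
Compound 3, `CCCCCCCCCCCCCOC(=O)CCC(=O)N1CCN(CCCOc2cc3c(Nc4ccc(F)c(Cl)c4)ncnc3cc2OC)CC1`, gives 93.8%.

Compound 3 stands highest of the three numbers shown. Against compound 1 the step of a number 23.8 percentage points higher from compound 1 to compound 3 (beyond the scatter) lies beyond the scatter, while against compound 2 the step of a number 8.7 percentage points higher from compound 2 to compound 3 (within the scatter) lies within it, so compound 3 and compound 2 cannot be ordered on these numbers.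

Compound 4, `CCCCCCCCCCCCCCOC(=O)CCC(=O)N1CCN(CCCOc2cc3c(Nc4ccc(F)c(Cl)c4)ncnc3cc2OC)CC1`, differs from compound 3 by methyl in place of hydrogen on a saturated chain carbon, ten or more bonds along the chain from an oxygen next to a carbonyl group. Among the compounds with values here, the steps that bear on it are those along the same chain: a number 15.1 percentage points higher from compound 1 to compound 2 (beyond the scatter), a number 23.8 percentage points higher from compound 1 to compound 3 (beyond the scatter) and a number 8.7 percentage points higher from compound 2 to compound 3 (within the scatter). The first two were modest and beyond the scatter, but the last, which adds several carbons at once, already stayed within the scatter, and the numbers are close to the top of the scale. For one added carbon, compound 4 is therefore expected to show a step of a number 1.2 percentage points higher from compound 3 to compound 4 (within the scatter), not beyond the scatter. Compound 4 is estimated at 95%, within the range 85% to 100%.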

Compound 4, a percentage reported as activity, at one concentration (the size of the read-out at that concentration, not a potency): 92.3%
Compound 4: the middle estimate sits 2.7 percentage points above what was measured; the measured number falls inside the stated range.
By their numbers in this assay, from the lowest: compound 1; then compounds 2, 4 and 3 (each within the scatter of the next).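

In this assay the methyl in place of hydrogen on a saturated chain carbon gives a number 1.5 percentage points lower from compound 3 to compound 4 (within the scatter) and so does not separate the two compounds. The wider comparisons give a number 7.2 percentage points higher from compound 2 to compound 4 (within the scatter) but a number 22.3 percentage points higher from compound 1 to compound 4 (beyond the scatter) and thereby extend the earlier picture: compound 1 stands apart from the three longer esters, while compounds 2, 3 and 4 cannot be ordered among themselves. No evidence is available on what lies behind these numbers.

The compounds shown leave open whether a longer chain would stay within the scatter of compounds 2, 3 and 4. They also leave open how a branched chain, a benzyl ester, a free carboxylic acid or an amide in place of the ester would read in this assay at this concentration.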